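Cathepsin S inhibitors: chloro to trifluoromethyl on two cores

The source may hold more compounds than are shown below. What is called first, only, known or untested is meant among the compounds shown, and "the series" means these compounds.

Of the compounds shown here, three have been measured in an assay on isolated protein for inhibition of cathepsin S (Homo sapiens), read by fluorescence, with a stated time of 20 min; a lower number here means a stronger inhibitor, a higher number a weaker inhibitor. Compound 1 `N#CCNC(=O)[C@@H]1C[C@@H](S(=O)(=O)c2ccccc2Cl)C[C@H]1C(=O)N1CCOCC1` gives 0.5 nM, and compound 2 `N#CCNC(=O)[C@@H]1C[C@@H](S(=O)(=O)c2ccccc2C(F)(F)F)C[C@H]1C(=O)N1CCOCC1` gives 0.9 nM. Compound 3 `N#CCNC(=O)[C@@H]1CN(S(=O)(=O)c2ccccc2Cl)C[C@H]1C(=O)N1CCOCC1` is built on a different core and gives 12 nM; the difference between its core and that of compound 1 is not broken down here. Compound 3 stands highest of the three numbers, and its steps to compound 2 and to compound 1 are both beyond the scatter.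

Within the first core, the change trifluoromethyl in place of chloro on an aromatic carbon made the step of a 1.8-fold higher number from compound 1 to compound 2 (0.26 log units; within the scatter). Compound 4 `N#CCNC(=O)[C@@H]1CN(S(=O)(=O)c2ccccc2C(F)(F)F)C[C@H]1C(=O)N1CCOCC1` has not yet been measured; it carries the same change on the second core, (trifluoromethyl in place of chloro on an aromatic carbon), and the place of the change is described in the same words for both pairs.

Because the step of a 1.8-fold higher number from compound 1 to compound 2 (0.26 log units; within the scatter) lies within the scatter, compound 4 is expected to show a step of about a 1.5-fold higher number from compound 3 to compound 4 (0.18 log units; within the scatter) from compound 3 in this assay. The estimate for compound 4 is 18 nM, with a likely range from 8 nM to 45 nM.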

Compound 4, half-maximal inhibitory concentration: 18 nM
Beside the measured number, compound 4's estimate shows no gap at the digits printed; low and high end bracket the measured number.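

In this assay, trifluoromethyl in place of chloro on the second core gives a 1.5-fold higher number from compound 3 to compound 4 (0.18 log units; within the scatter), so the two compounds cannot be told apart in this assay. Set beside the same change on the first core, the two steps agree: the same change on two cores in this assay, a 1.8-fold higher number (0.26 log units; within the scatter) from compound 1 to compound 2 and a 1.5-fold higher number (0.18 log units; within the scatter) from compound 3 to compound 4, 1.2-fold (0.08 log units) apart, within the scatter of two such steps

This shows that the change carried from one core to the other without a step that stands clear of the scatter, and that the gap between the two cores remains with either group in place. Going by these compounds alone, it does not show that a real effect of a particular size transfers, since both steps are small and rest on only two pairs, and a change with a larger step would test transfer more strictly.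

Only 2-chlorophenyl and 2-(trifluoromethyl)phenyl appear among the compounds shown, so it remains open how a methoxy group or an amine at the same place would behave on either core. Going by these compounds, it also remains open whether the agreement would extend to a third core.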